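This account rests on a few compounds, and the source may have more. Where it says the series, first, only, none or still open, it means among the compounds named here.

Compound 1 `O=C(NC1CCCCC1)NS(=O)(=O)N1CCC(CCNC(=O)C(F)(F)F)CC1` carries a cyclohexyl on its amide-type nitrogen and a trifluoromethyl on its carbonyl carbon. In a functional assay on the whole organism (blood) with Rattus norvegicus as the target, with stated times of 24 h and 1 h, at a dose of 5 mg/kg by the intraperitoneal route (a lower number here means a weaker effect, a higher number a stronger effect of the compound at the dose given), compound 1 gives 13%. Compound 2 `O=C(NC[C@@H]1C[C@@H]2C=C[C@@H]1C2)NS(=O)(=O)N1CCC(CCNC(=O)C(F)(F)F)CC1` differs from it by the change (a group of 8 heavy atoms (8 carbon; 2 five-membered non-aromatic rings of carbon only) in place of a group of 6 heavy atoms (6 carbon; one six-membered non-aromatic ring of carbon only), on an amide-type nitrogen), and in this assay compound 2 gives 22%; the step of a number 9 percentage points higher from compound 1 to compound 2 (within the scatter) is small. Compound 3 `O=C(NC1CCCCC1)NS(=O)(=O)N1CCC(CCNC(=O)c2cccc3cccnc23)CC1` instead differs from compound 1 by quinolin-8-yl in place of trifluoromethyl on a carbonyl carbon, and in this assay compound 3 gives 37%, the highest of the three numbers, with the step of a number 24 percentage points higher from compound 1 to compound 3 (beyond the scatter).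

Compound 4 `O=C(NC[C@@H]1C[C@@H]2C=C[C@@H]1C2)NS(=O)(=O)N1CCC(CCNC(=O)c2cccc3cccnc23)CC1` has not yet been measured. It differs from compound 3 by a group of 8 heavy atoms (8 carbon; 2 five-membered non-aromatic rings of carbon only) in place of a group of 6 heavy atoms (6 carbon; one six-membered non-aromatic ring of carbon only), on an amide-type nitrogen, the same change that leads from compound 1 to compound 2, made here on the core of compound 3, whose difference from the core of compound 1 is quinolin-8-yl in place of trifluoromethyl on a carbonyl carbon. Among the compounds with values here, because the earlier step was a number 9 percentage points higher from compound 1 to compound 2 (within the scatter), a similar step, a number 9 percentage points higher from compound 3 to compound 4 (within the scatter), is expected for compound 4, resting on only that one pair. Compound 4 is therefore estimated at 46%, between 30% and 62%.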

Compound 4, a percentage reported as activity, at one dose (the size of the read-out at that dose, not a potency): 34%
Compound 4: middle estimate off by 12 percentage points, on the high side; the range from low to high includes it.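

In this assay, putting the group of 8 heavy atoms in place of cyclohexyl on the amide-type nitrogen now gives a number 3 percentage points lower from compound 3 to compound 4 (within the scatter), and the two steps for this change do not differ measurably: the same change on two cores in this assay, a number 9 percentage points higher (within the scatter) from compound 1 to compound 2 and a number 3 percentage points lower (within the scatter) from compound 3 to compound 4, 12 percentage points apart, within the scatter of two such steps. Quinolin-8-yl in place of trifluoromethyl on the carbonyl carbon gives a number 12 percentage points higher from compound 2 to compound 4 (beyond the scatter), so this change also carries over, pointing upward on both cores: the same change on two cores in this assay, a number 24 percentage points higher (beyond the scatter) from compound 1 to compound 3 and a number 12 percentage points higher (beyond the scatter) from compound 2 to compound 4, 12 percentage points apart, within the scatter of two such steps. This shows that neither change depends detectably on the core carrying it, but it does not show that the steps are equal or that they add up in general, as each comparison rests on one pair of steps in a single set of four compounds.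

The compounds shown leave open whether other groups on the carbonyl carbon, such as phenyl or a methyl, would match quinolin-8-yl. They also leave open how an open chain such as n-butyl or a smaller ring such as cyclopentyl would behave on the amide-type nitrogen.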